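From chloromethyl to phenyl on a carbonyl carbon

A few compounds are considered here, and "the series" means these few. Any claim that something is new, unique, unknown or untested is made for them only; others in the source may bear on it.

- Compound 1 `CCOC(=O)N1CCCc2cc(S(=O)(=O)N3CC(c4ccccc4)NC3=O)ccc21`: > 20000 nM (a limit)
- Compound 2 `O=C(CCl)N1CCCc2cc(S(=O)(=O)N3CC(c4ccccc4)NC3=O)ccc21`: 1100 nM

Among the compounds with values here, in a functional assay on K562 cells (Homo sapiens) for antiproliferative activity, read by MTT assay (on this read-out lower numbers stand for stronger inhibition and higher numbers for weaker inhibition), compound 2 gives 1100 nM as the only true number so far. Compound 1 stands at > 20000 nM as a limit of the assay, not a number. Compound 3 `O=C(c1ccccc1)N1CCCc2cc(S(=O)(=O)N3CC(c4ccccc4)NC3=O)ccc21` has phenyl in place of chloromethyl on a carbonyl carbon and is still unmeasured. Within the data shown here, only one measured step changes this place, an at least 18-fold lower number from compound 1 to compound 2 (1.25 log units; beyond the scatter) and that large step brought chloromethyl in, so a higher number is expected in this assay when chloromethyl leaves. The expected step is a 3.6-fold higher number from compound 2 to compound 3 (0.56 log units; beyond the scatter) in size. Compound 3 is estimated at 4000 nM with an expected range from 700 nM to 20000 nM in this estimate.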

Compound 3, half-maximal inhibitory concentration: 1220 nM
Compound 3: the middle estimate sits 3.3-fold (0.52 log units) above what was measured; the measured number falls inside the stated range.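

In this assay, phenyl in place of chloromethyl on this carbonyl carbon gives a 1.1-fold higher number from compound 2 to compound 3 (0.04 log units; within the scatter), so the two groups cannot be told apart here and chloromethyl is not required for this level of inhibition. Phenyl in place of ethoxy gives an at least 16-fold lower number from compound 1 to compound 3 (1.21 log units; beyond the scatter), so two quite different groups both outdo ethoxy. The size of that step is only a bound, as compound 1 carries a limit and not a number: the limit of > 20000 nM in this assay, at which 1 of the 3 values shown sits.

The compounds shown leave open how an aminomethyl group or a pyridine ring on this carbonyl carbon would read. They also leave open whether groups beyond these two would likewise outdo ethoxy.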